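The source may report more compounds than this note shows. Statements on the series, on what has been measured and on what is new or still open speak of the compounds shown alone.

Measured in an ADME assay on HEK293 cells (Homo sapiens) for cytotoxicity, with a stated time of 72 h; on this read-out higher numbers stand for an effect only at larger amounts of compound and lower numbers for an effect already at smaller amounts:
- compound 1 `Cc1ccc(-c2nc3ccccc3s2)cc1NC(=O)c1cc([N+](=O)[O-])c(N2CCC(C(=O)O)CC2)cc1Cl` gives > 25000 nM as a limit
- compound 2 `COc1ccc(-c2nc3ccccc3s2)cc1NC(=O)c1cc([N+](=O)[O-])ccc1Cl` gives > 25000 nM as a limit

Compound 2 gives > 25000 nM in this assay as a limit of the assay and not a number. Compound 1 likewise gives > 25000 nM as a limit. For the measured compounds named here, the series therefore stands at the limit of > 25000 nM in this assay, at which 2 of the 2 values shown sit, and has no numerical value so far.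

Compound 3 `COc1ccc(-c2nc3ccccc3s2)cc1NC(=O)c1cc([N+](=O)[O-])c(N2CCC(C(=O)O)CC2)cc1Cl` keeps the core of compound 2 and has 4-carboxypiperidin-1-yl in place of hydrogen on an aromatic carbon, ortho to a nitro group, meta to a chloro group and para to a large group (4-carboxypiperidin-1-yl in place of hydrogen on an aromatic carbon). Going by the values given here, compound 1 also carries 4-carboxypiperidin-1-yl, but no measured step isolates this change.

Since compound 1 sits at the limit of > 25000 nM even with this group, no change beyond the scatter is expected in this assay and no direction can be given. The expected size is a step that the limit leaves unreadable from compound 2 to compound 3 on this estimate. Compound 3 is expected at 30000 nM with an estimated range from 12000 nM to 60000 nM in this read-out.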

Compound 3, half-maximal effective concentration: > 25000 nM
Compound 3: only a limit was reported; the forecaster's own chance of this, stated with the estimate: 90%; the middle value does not contradict the limit.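

In this assay compound 3 gives > 25000 nM, a limit of the assay and not a number. The steps to compound 3 from compound 1 and from compound 2 therefore cannot be read. The compounds shown leave open how far each of the three lies from that limit, and whether 4-carboxypiperidin-1-yl or methoxy in place of methyl changes this read-out at all.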